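Bromo to formyl on the fused core: compound 3 pending

The source may report more compounds than this note shows. Statements on the series, on what has been measured and on what is new or still open speak of the compounds shown alone.

Measured so far:
- compound 1, `Cc1ccc(-c2nc3sc(Cc4ccc(Cl)cc4)nn3c2Br)cc1`, in a functional assay on HeLa cells (Homo sapiens) for cytotoxicity, with a stated time of 72 h; a lower number here means a stronger inhibitor, a higher number a weaker inhibitor: > 250000 nM, a limit of the assay.
- compound 2, `Clc1ccc(Cc2nn3c(Br)c(-c4ccccc4)nc3s2)cc1`, in this assay: > 250000 nM, a limit of the assay.

Compound 2 stands only at a limit in this assay, with no number behind it. Going by the values given here, the one measured step, a step that the two limits leave unreadable from compound 1 to compound 2, hydrogen in place of methyl on an aromatic carbon, cannot be read in size, since (the limit of > 250000 nM in this assay, at which 2 of the 2 values shown sit).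

Compound 3, `O=Cc1c(-c2ccccc2)nc2sc(Cc3ccc(Cl)cc3)nn12`, is the next compound in the series. Its change from compound 2 is formyl in place of bromo on an aromatic carbon. Among the compounds with values here, no measured step touches that position or that kind of exchange, so nothing among the measured compounds speaks to the direction or size of the step in this assay; the only guide is that compound 2 sits at the limit.

Compound 3 is therefore expected to remain near or at the limit, with the step of a number no higher from compound 2 to compound 3 (the limit leaves the size open) estimated as no more than the scatter. The estimate for compound 3 in this assay is 250000 nM, with a range from 40000 nM to 1000000 nM.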

Compound 3, half-maximal inhibitory concentration: 45000 nM
Estimate against measurement, compound 3: 5.6-fold (0.74 log units) above; low and high end bracket the measured number.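

In this assay, going by these compounds alone, the aromatic carbon next to the ring nitrogen is the first place where a change can be read: formyl in place of bromo gives an at least 5.5-fold lower number from compound 2 to compound 3 (0.74 log units; beyond the scatter). Compound 3 is also the first compound shown with a number rather than a limit, and the earlier exchange of hydrogen for methyl on an aromatic carbon cannot be read. The size of the new step is a lower bound and not a measured gap, because its starting point is a limit: the limit of > 250000 nM in this assay, at which 2 of the 3 values shown sit.

Only bromo and formyl are shown on this carbon, so it remains open whether the lower number follows from formyl itself or would also appear with other groups there, such as hydroxymethyl, a carboxylic acid or an amine. Formyl is also shown only alongside the phenyl group, which leaves open whether a methyl on that phenyl would change the reading now that a number is available at this position.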